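This account rests on a few compounds, and the source may have more. Where it says the series, first, only, none or still open, it means among the compounds named here.

Compound 1 `CC1CC1COc1cccc2ccc(N)nc12`: 1640 nM
Compound 2 `Nc1ccc2cccc(OC3CCCC3)c2n1`: > 2000 nM

In an assay on cells with melanin-concentrating hormone receptor 1 (Homo sapiens) as the target, read by radioligand binding (on this read-out higher numbers stand for weaker inhibition and lower numbers for stronger inhibition), compound 1 gives 1640 nM. Compound 2 reaches only (the limit of > 2000 nM in this assay, at which 1 of the 2 values shown sits), which is a limit of the assay and not a number. For the measured compounds named here, the step of an at least 1.2-fold higher number from compound 1 to compound 2 (0.08 log units; that floor lies within the scatter) is the only measured change of the group on an oxygen on an aromatic ring. Compound 3 `CC(C)(C)CCOc1cccc2ccc(N)nc12` differs from compound 2 by 3,3-dimethylbutyl in place of cyclopentyl on an oxygen on an aromatic ring. Going by the values given here, no measured step covers this exact exchange, and the one step at this place stays within the scatter, so no movement beyond the scatter is expected in this assay. Compound 3 is therefore estimated at 2500 nM, with a range from 1200 nM to 6000 nM. The expected step is a step that the limit leaves unreadable from compound 2 to compound 3.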

Compound 3, half-maximal inhibitory concentration: 201 nM
Compound 3: middle estimate off by 12-fold (1.09 log units), on the high side; measured number below the stated range.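

In this assay, for the compounds shown here, the group on this oxygen can move the number well beyond the scatter, which the one earlier step did not show. Putting 3,3-dimethylbutyl in place of cyclopentyl gives an at least 9.9-fold lower number from compound 2 to compound 3 (0.99 log units; beyond the scatter), and putting neopentyl in place of 2-methylcyclopropyl on the saturated chain carbon gives an 8.2-fold lower number from compound 1 to compound 3 (0.91 log units; beyond the scatter). The first step is only a floor because compound 2 stands at a limit of the assay and not a number: the limit of > 2000 nM in this assay, at which 1 of the 3 values shown sits.

From the compounds shown here alone, whether a longer chain or an amine at the end of the chain would keep this lower number remains open.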